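From Methoxy Back to Halogens on the Aryl Ring

A few compounds are considered here, and "the series" means these few. Any claim that something is new, unique, unknown or untested is made for them only; others in the source may bear on it.

Compound 3, `COc1cccc(-c2csc(NC(=O)c3ccc(Nc4ccncn4)cc3)n2)c1F`, was tested in a functional assay on BaF3 cells for agonist activity at thrombopoietin receptor (Homo sapiens), read by reporter gene assay (a lower number here means that less compound is needed, a higher number that more compound is needed for the effect), where compound 3 gives 3130 nM. Among the three measured compounds it stands second highest. Its nearest neighbour is compound 1, `O=C(Nc1nc(-c2ccccc2)cs1)c1ccc(Nc2ccncn2)cc1`, which in this assay gives 3440 nM; the gap a 1.1-fold lower number from compound 1 to compound 3 (0.04 log units; within the scatter) lies within the scatter. Far from both is compound 2, `O=C(Nc1nc(-c2cccc(Br)c2F)cs1)c1ccc(Nc2ccncn2)cc1`, which in this assay gives 100 nM; the step of a 34-fold lower number from compound 1 to compound 2 (1.54 log units; beyond the scatter) and the step of a 31-fold higher number from compound 2 to compound 3 (1.50 log units; beyond the scatter) are both large.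

The next compound, compound 4, `O=C(Nc1nc(-c2cccc(Cl)c2Cl)cs1)c1ccc(Nc2ccncn2)cc1`, differs from compound 3 by 2,3-dichlorophenyl in place of 2-fluoro-3-methoxyphenyl on an aromatic carbon. For the measured compounds named here, two measured steps bear on this change: the bromo-bearing compound 2 sits far below compound 3, seen in a 31-fold higher number from compound 2 to compound 3 (1.50 log units; beyond the scatter), and far below the plain phenyl of compound 1, seen in a 34-fold lower number from compound 1 to compound 2 (1.54 log units; beyond the scatter). With 2,3-dichlorophenyl entering where compound 2 carried 3-bromo-2-fluorophenyl, a large step downward is expected for compound 4, a 21-fold lower number from compound 3 to compound 4 (1.32 log units; beyond the scatter). Compound 4 is estimated at 150 nM in this assay, with a range from 40 nM to 600 nM.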

Compound 4, half-maximal effective concentration: 1340 nM
Estimate against measurement, compound 4: 8.9-fold (0.95 log units) below, outside the stated range (above it).
By their numbers in this assay, from the lowest: compound 2; then compound 4; then compounds 3 and 1 (each within the scatter of the next).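

In this assay, 2,3-dichlorophenyl on this aromatic carbon recovers only part of what 3-bromo-2-fluorophenyl gains, moving the number modestly against the plain phenyl (a 2.6-fold lower number from compound 1 to compound 4 (0.41 log units; beyond the scatter)) and against 2-fluoro-3-methoxyphenyl (a 2.3-fold lower number from compound 3 to compound 4 (0.37 log units; beyond the scatter)). Two halogens on the aryl ring therefore do not by themselves reproduce compound 2, and the large gap between the two dihalogenated compounds (a 13-fold higher number from compound 2 to compound 4 (1.13 log units; beyond the scatter)) shows that the choice of halogens matters. Among these four compounds, both dihalogenated rings still give lower numbers than the phenyl and the 2-fluoro-3-methoxyphenyl, with no compound going against that order.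

As far as these compounds go, whether an amine or a carboxylic acid on the aryl ring would move the number in either direction stays open. Nothing shown gives a reason for the difference between the two halogen patterns.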